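Working notes: the step from compound 2 to compound 4

The source may report more compounds than this note shows. Statements on the series, on what has been measured and on what is new or still open speak of the compounds shown alone.

Values from a functional assay on Jurkat cells (Homo sapiens) for inhibition (a higher number here means a weaker inhibitor, a lower number a stronger inhibitor), for the measured compounds:
- compound 1 `Cc1c(C(=O)N[C@H](C(=O)NC(CC(=O)O)C(=O)CF)C(C)C)n(C)c2ccccc12` gives 1300 nM
- compound 2 `C[C@H](NC(=O)C(=O)NCc1ccccc1)C(=O)N[C@@H](CC(=O)O)C(=O)COc1c(F)c(F)cc(F)c1F` gives 300 nM
- compound 3 `C[C@H](NC(=O)C(=O)Nc1ccccc1-c1ccccc1)C(=O)N[C@@H](CC(=O)O)C(=O)COC(=O)c1c(F)c(F)cc(F)c1F` gives 130 nM

Compound 2 stands in the middle of the three numbers, and its gaps to compound 1 and compound 3 both lie beyond the scatter. Compound 4 `C[C@H](NC(=O)C(=O)Nc1ccc2c(c1)CCC2)C(=O)N[C@@H](CC(=O)O)C(=O)COc1c(F)c(F)cc(F)c1F` differs from compound 2 by 2,3-dihydro-1H-inden-5-yl in place of benzyl on an amide-type nitrogen, which places 2,3-dihydro-1H-inden-5-yl in place of benzyl on an amide-type nitrogen. Within the data shown here, no measured pair isolates this change. Among the measured compounds shown here, the only hint is compound 3 at 130 nM, which differs from compound 2 in more than one place, so a modest step to a lower number is expected in this assay, near the edge of the scatter. The estimate is a 2.0-fold lower number from compound 2 to compound 4 (0.30 log units; within the scatter) as the expected step. Compound 4 is estimated at 150 nM with 50 nM to 450 nM as the expected range.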

Compound 4, half-maximal inhibitory concentration: 200 nM
Compound 4: middle estimate off by 1.3-fold (0.12 log units), on the low side; low and high end bracket the measured number.
By their numbers in this assay, from the lowest: compounds 3, 4 and 2 (each within the scatter of the next, the first and the last beyond it); then compound 1.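

In this assay, 2,3-dihydro-1H-inden-5-yl in place of benzyl on an amide-type nitrogen gives a 1.5-fold lower number from compound 2 to compound 4 (0.18 log units; within the scatter). Among these compounds, this is the first pair to isolate a change at this position, and it shows that the two groups are not told apart here, although the entering group adds a five-membered non-aromatic ring. Nothing available explains this result. Open, as far as these compounds go, is whether a longer chain such as phenethyl in place of benzyl keeps the value. Also open, from the compounds shown here alone, is how an amine or a carboxylic acid on the aromatic ring would read at this position.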